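Demethylation of the aryl methoxy group in a pyrazole urea

The source may hold more compounds than are shown below. What is called first, only, known or untested is meant among the compounds shown, and "the series" means these compounds.

Compound 1: `COc1cc(Cl)cc(-c2nn(-c3cccc(NC(=O)Nc4ccc(Cl)c(C(F)(F)F)c4)c3)cc2-c2ccncc2)c1` gives -29% in a functional assay on CCRF-CEM cells (Homo sapiens) for inhibition, read by sulforhodamine B assay, with a stated time of 48 h, tested at 100 uM; a higher number here means a weaker effect of the compound at the concentration tested, a lower number a stronger effect.
Compound 2: `COc1cc(Cl)cc(-c2nn(-c3cccc(NC(=O)c4cccc(C(F)(F)F)c4)c3)cc2-c2ccncc2)c1` gives 32% in this assay.

Within the data shown here, compound 1 stands as the lower of the two numbers in this assay; the one measured step, a number 61 percentage points higher from compound 1 to compound 2 (beyond the scatter), is large but concerns the group on the carbonyl carbon, not the change followed here. Compound 3 is `O=C(Nc1cccc(-n2cc(-c3ccncc3)c(-c3cc(O)cc(Cl)c3)n2)c1)Nc1ccc(Cl)c(C(F)(F)F)c1`. It differs from compound 1 by hydrogen in place of methyl on an oxygen on an aromatic ring. Among the measured compounds shown here, no measured step bears on this change, so no step beyond the scatter in this assay is expected in either direction. The expected step is a number 14 percentage points higher from compound 1 to compound 3 (beyond the scatter), and compound 3 is estimated at -15%, within -55% to 30%.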

Compound 3, a percentage reported as activity, at one concentration (the size of the read-out at that concentration, not a potency): -3%
The estimate for compound 3 lay 12 percentage points below the measured number, and the stated range covers the measured number.
By their numbers in this assay, from the lowest: compound 1; then compound 3; then compound 2.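

Hydroxy in place of methoxy on the 3-chloro-5-methoxyphenyl group gives, in this assay, a number 26 percentage points higher from compound 1 to compound 3 (beyond the scatter). This shows that the position responds to what sits on this oxygen, and that removing the methyl modestly weakens the effect at the concentration tested. Nothing available explains this step.

As far as these compounds go, whether an ethyl on this oxygen, or an amine in place of it, would shift the number further remains open. So does whether the same change would act alike on the amide of compound 2.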